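3-Fluorophenyl to 3-cyanophenyl: an expected step

The source may hold more compounds than are shown below. What is called first, only, known or untested is meant among the compounds shown, and "the series" means these compounds.

Of the compounds shown here, three with a shared core have numbers so far in a functional assay on HL-60 cells (Homo sapiens) for inhibition, read by MTT assay, with a stated time of 72 h (on this read-out higher numbers stand for weaker inhibition and lower numbers for stronger inhibition), for comparison. Compound 1 (`Cc1ccc(C)c(N2CCN(C(=O)c3oc(C)nc3-c3ccccc3)CC2)c1`) reads 31.3 nM there, compound 2 (`Cc1cc(C)cc(N2CCN(C(=O)c3oc(C)nc3-c3ccccc3)CC2)c1`) reads 34.5 nM there and compound 3 (`Cc1nc(-c2ccccc2)c(C(=O)N2CCN(c3cccc(F)c3)CC2)o1`) reads 45 nM there, which places compound 3 within the scatter of both others.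

Compound 4 (`Cc1nc(-c2ccccc2)c(C(=O)N2CCN(c3cccc(C#N)c3)CC2)o1`) has cyano in place of fluoro on an aromatic carbon, meta to a large group (cyano in place of fluoro on an aromatic carbon). Among the measured compounds shown here, no measured step exchanges these two groups. The nearest evidence is the exchange of one aryl group for another on the same amine nitrogen in a ring: a 1.4-fold higher number from compound 1 to compound 3 (0.16 log units; within the scatter) for 3-fluorophenyl in place of 2,5-dimethylphenyl, a 1.3-fold higher number from compound 2 to compound 3 (0.12 log units; within the scatter) for 3-fluorophenyl in place of 3,5-dimethylphenyl and a 1.1-fold higher number from compound 1 to compound 2 (0.04 log units; within the scatter) for 3,5-dimethylphenyl in place of 2,5-dimethylphenyl. All three lie within the scatter, so no step beyond the scatter and no clear direction is expected in this assay here. The expected step is a 1.1-fold higher number from compound 3 to compound 4 (0.05 log units; within the scatter) and it stays within the scatter. The estimate for compound 4 is 50 nM with an expected range of 20 nM to 120 nM in this assay for this compound.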

Compound 4, half-maximal inhibitory concentration: 39.6 nM
The estimate for compound 4 lay 1.3-fold (0.10 log units) above the measured number; the measured number falls inside the stated range.
By their numbers in this assay, from the lowest: compounds 1, 2, 4 and 3 (each within the scatter of the next).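

In this assay the change from fluoro to cyano on an aromatic carbon gives a 1.1-fold lower number from compound 3 to compound 4 (0.06 log units; within the scatter) and so adds a nitrile, with its 2 heavy atoms and 1 hydrogen-bond acceptor, at this position without a step beyond the scatter. Against the two dimethylphenyl compounds the picture is the same, with a 1.1-fold higher number from compound 2 to compound 4 (0.06 log units; within the scatter) and a 1.3-fold higher number from compound 1 to compound 4 (0.10 log units; within the scatter) as the steps, so the aryl groups on the amine nitrogen in a ring now include one with a hydrogen-bond acceptor, which the earlier compounds, carrying only fluoro or methyl groups there, did not show, and all four compounds stand within the scatter of one another. No measurement in hand offers a reason why the numbers stay so close together.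

Going by these compounds, whether this holds for other groups at the same place on the aromatic ring remains open, for instance a carboxylic acid, an aminomethyl group or a longer alkyl chain in place of the cyano. The series also leaves open whether a second cyano on the same ring would move the number beyond the scatter in this assay or leave it where these four compounds stand.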